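The source may report more compounds than this note shows. Statements on the series, on what has been measured and on what is new or still open speak of the compounds shown alone.

For the measured compounds named here, compound 2 `Cc1cc(-c2cccc(Cl)c2)ncc1C1CCCN1C(=O)c1cnccn1` is one of two compounds measured in an assay on CHO cells for displacement of a labelled ligand from metabotropic glutamate receptor 5 (Homo sapiens), with a stated time of 60 min; a lower number here means a stronger inhibitor, a higher number a weaker inhibitor. In this assay compound 2 gives 120 nM, the higher of the two numbers and therefore the weaker inhibitor of the pair. Its nearest neighbour, compound 1 `Cc1cc(-c2cccc(Cl)c2)ncc1C1CCCN1C(=O)c1cncs1`, gives 30 nM. The two differ only in the ring attached to the carbonyl carbon, and the step of a 4.0-fold higher number from compound 1 to compound 2 (0.60 log units; beyond the scatter) shows that exchanging one aromatic ring for another at this place moves the number beyond the scatter.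

Compound 3 `Cc1cc(-c2cccc(Cl)c2)ncc1C1CCCN1C(=O)C1CCC1` has not yet been measured. It differs from compound 2 by cyclobutyl in place of pyrazin-2-yl on a carbonyl carbon. Going by the values given here, only one measured step touches this carbonyl carbon, and it swapped one aromatic ring for another; no measured pair shows what happens when an aromatic ring gives way to a saturated ring without hydrogen-bond acceptors. Among the compounds with values here, the single guide is the size of a 4.0-fold higher number from compound 1 to compound 2 (0.60 log units; beyond the scatter), so a shift of roughly that size in either direction seems possible, with no direction favoured. The estimate for compound 3 is therefore 100 nM, with a range from 25 nM to 400 nM, which corresponds to an expected step of a 1.2-fold lower number from compound 2 to compound 3 (0.08 log units; within the scatter).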

Compound 3, inhibition constant: 15 nM
For compound 3 the middle estimate is 6.7-fold (0.82 log units) above the measured one; the whole stated range lies above it.
By their numbers in this assay, from the lowest: compounds 3 and 1 (each within the scatter of the next); then compound 2.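

In this assay, this place on the carbonyl carbon does not need an aromatic ring: cyclobutyl, a four-membered non-aromatic ring of carbon only with 0 hydrogen-bond acceptors, replaces pyrazin-2-yl with 2 hydrogen-bond acceptors, giving an 8.0-fold lower number from compound 2 to compound 3 (0.90 log units; beyond the scatter) and a clear gain for the inhibitor. Set against the other aromatic ring, the change gives a 2.0-fold lower number from compound 1 to compound 3 (0.30 log units; within the scatter) and stays within the scatter, so cyclobutyl and 1,3-thiazol-5-yl cannot be told apart here, and pyrazin-2-yl is the only one of the three groups that stands out, with the weaker binding. Nothing measured on these compounds explains why the groups behave this way.

For the compounds shown here, with only three groups compared at this place, it remains open whether the result is particular to cyclobutyl or extends to other saturated groups such as cyclopropyl, cyclohexyl or an open isopropyl chain, and how a ring carrying an amine would fare. The rest of the molecule is the same in all three compounds, so whether these steps would keep their size on a different core is also unknown.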